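The source may report more compounds than this note shows. Statements on the series, on what has been measured and on what is new or still open speak of the compounds shown alone.

Compound 1 `O=C(O)c1cc(-c2cnc(C(=O)CCc3ccc(-c4ccccc4)cc3)o2)ccn1`, compound 2 `COC(=O)c1cccc(-c2cnc(C(=O)CCc3ccc(OC4CCN(C(=O)OC(C)(C)C)CC4)cc3)o2)n1` and compound 3 `COC(=O)c1ccc(-c2cnc(C(=O)CCc3ccc(COc4ccccc4)cc3)o2)nc1` were tested in an assay for inhibition of Fatty-acid amide hydrolase 1 (Rattus norvegicus); on this read-out lower numbers stand for stronger inhibition and higher numbers for weaker inhibition. Compound 1 gives 50 nM, the highest of the three numbers; compound 2 gives 32 nM, which lies within the scatter of compound 1, while compound 3 gives 3.5 nM, a clearly lower number. Compound 4 `COC(=O)c1cccc(-c2cnc(C(=O)CCc3ccc(-c4ccccc4)cc3)o2)n1` is compound 1 with a single change: 6-(methoxycarbonyl)pyridin-2-yl in place of 2-carboxypyridin-4-yl on an aromatic carbon. Compound 2 carries the same 6-(methoxycarbonyl)pyridin-2-yl group on the shared core, with a different tail. Because compound 2 gives 32 nM while compound 1 gives 50 nM, only a small move is expected here. The expected step is a 2.3-fold lower number from compound 1 to compound 4 (0.36 log units; beyond the scatter), a modest move toward a lower number. Compound 4 is estimated at 22 nM, between 6 nM and 80 nM.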

Compound 4, inhibition constant: 1.2 nM
Beside the measured number, compound 4's estimate is 18-fold (1.26 log units) above it, and the stated range ends above it.
By their numbers in this assay, from the lowest: compound 4; then compound 3; then compounds 2 and 1 (each within the scatter of the next).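

With the rest of the molecule held fixed, changing only the group on the aromatic carbon next to the ring oxygen gives a 42-fold lower number from compound 1 to compound 4 (1.62 log units; beyond the scatter) in this assay, so inhibition depends strongly on this group. The earlier compounds shown here differ in more than one place and could not show this. Nothing here explains the size of the step. The swap alters both the carboxy versus methoxycarbonyl group and the way the pyridine ring is attached, and the two effects cannot be separated. A 6-carboxypyridin-2-yl or 2-(methoxycarbonyl)pyridin-4-yl group at this position would tell them apart.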